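The source may hold more compounds than are shown below. What is called first, only, known or untested is meant among the compounds shown, and "the series" means these compounds.

Measured so far in an ADME assay on Raji cells (Homo sapiens) for cytotoxicity, with a stated time of 72 h; a lower number here means that less compound is needed, a higher number that more compound is needed for the effect:

Compound 1 `Cc1cc(NC(=O)Nc2ccc(C)c(Cl)c2)c2ccccc2n1`: > 25000 nM (a limit, not a number)
Compound 2 `CSc1ccc(NC(=O)Nc2cc(C)nc3ccccc23)cc1`: > 25000 nM (a limit, not a number)

Compound 2 therefore has no exact value in this assay. Among the compounds with values here, its result is a limit of the assay, and the only other measured compound stands at the same limit: the limit of > 25000 nM in this assay, at which 2 of the 2 values shown sit.

The next compound, compound 3 `CC(=O)c1ccc(NC(=O)Nc2cc(C)nc3ccccc23)cc1`, keeps the core of compound 2 and changes one group. It has acetyl in place of methylsulfanyl on an aromatic carbon, para to a large group (acetyl in place of methylsulfanyl on an aromatic carbon).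

Within the data shown here, no pair of measured compounds differs in just one place, so there is no measured step to serve as a guide. With compound 2 at > 25000 nM, the expectation is no shift beyond the usual scatter, in either direction, and another limit is the most likely result. The expected change is a number no higher from compound 2 to compound 3 (the limit leaves the size open). For compound 3 the estimated value is 25000 nM, with an expected range from 12000 nM to 50000 nM.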

Compound 3, half-maximal effective concentration: > 25000 nM
Compound 3 ended at the assay's limit (the forecaster's own chance of this, stated with the estimate: 85%); the middle value lies on the limit itself.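

In this assay no step can be read from compound 2 to compound 3, since each result is a limit and not a number: the limit of > 25000 nM in this assay, at which 3 of the 3 values shown sit.

The compounds shown leave open whether any compound with this shared core gives an exact value in this assay and how acetyl and methylsulfanyl compare there.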